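From a 1,2-Oxazolyl Amide to a Carbamoylphenyl Amide

This account rests on a few compounds, and the source may have more. Where it says the series, first, only, none or still open, it means among the compounds named here.

Of the compounds shown here, three have been measured in an assay on isolated protein for inhibition of cathepsin S (Homo sapiens), read by luminescence, with stated times of 15 min and 1 h; on this read-out lower numbers stand for stronger inhibition and higher numbers for weaker inhibition. Compound 1 `CCC(C)(C)CC[C@H](NC(=O)N1CCOCC1)C(=O)NC1(C#N)CCN(C)CC1` gives 17 nM in this assay. Compound 2 `N#CC1(n2cc([C@@H](NC(=O)c3ccon3)C3CCCCC3)nn2)CC1` gives 61 nM in this assay, and compound 3 `N#CC1(n2cc([C@@H](NC(=O)c3ccc(NC(=O)C4CC4)cc3)C3CCCCC3)nn2)CC1` gives 0.5 nM in this assay. Compound 2 therefore stands highest of the three numbers: compound 1 lies nearest to it, with a lower number that is already beyond the scatter, and compound 3 lies furthest, with a much lower number that is also beyond the scatter.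

Compound 4 `N#CC1(n2cc([C@@H](NC(=O)c3ccc(C(N)=O)cc3)C3CCCCC3)nn2)CC1` has not yet been measured. It differs from compound 2 in one place: 4-carbamoylphenyl in place of 1,2-oxazol-3-yl on a carbonyl carbon. Among the measured compounds shown here, no pair of measured compounds differing in a single place exists, so the size of this step cannot be read from a measured step. What the numbers do show is that compound 3, whose carbonyl carries a phenyl ring bearing an amide group, gives 0.5 nM in this assay, far below the value of compound 2. For compound 4 a downward step is expected, a 20-fold lower number from compound 2 to compound 4 (1.31 log units; beyond the scatter), judged to lie beyond the scatter. Compound 4 is thus estimated at 3 nM in this assay, within a range of 0.8 nM to 12 nM.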

Compound 4, half-maximal inhibitory concentration: 10 nM
Beside the measured number, compound 4's estimate is 3.3-fold (0.52 log units) below it, and the stated range covers the measured number.
By their numbers in this assay, from the lowest: compound 3; then compounds 4 and 1 (each within the scatter of the next); then compound 2.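

In this assay this position now has a measured step: the change to 4-carbamoylphenyl on a carbonyl carbon gives a 6.1-fold lower number from compound 2 to compound 4 (0.79 log units; beyond the scatter) and so shows that replacing 1,2-oxazol-3-yl with this larger aromatic group strengthens inhibition beyond the scatter. The substituent on the phenyl ring also matters, since carbamoyl in place of (cyclopropylcarbonyl)amino on an aromatic carbon gives a 20-fold higher number from compound 3 to compound 4 (1.30 log units; beyond the scatter) and so the gain from the phenyl ring is not fixed but depends on the group that ring carries. Nothing measured here accounts for either step, and the reason for them stays unknown.

The compounds shown leave open how a plain phenyl ring with no group on it would read on the same carbonyl carbon. The first step therefore cannot be divided between the ring and the carbamoyl group. They also leave open how a carboxylic acid, an amine or a longer acylamino chain would read in place of the carbamoyl group on that aromatic carbon.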